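The compounds below may be only part of what the source reports. "The series", "measured", "known", "first", "only" and "open" are said of these compounds alone.

Working notes on the series. In a functional assay on PC-3 cells (Homo sapiens) for cytotoxicity, read by MTT assay, with a stated time of 72 h (on this read-out higher numbers stand for weaker inhibition and lower numbers for stronger inhibition), compound 2 `CCc1ccc(-c2ccnc(C(=O)Nc3ccc(Oc4ccnc5[nH]ccc45)c(F)c3)c2)cc1` gives 2960 nM. Compound 1 `Cc1ccc(-c2ccnc(C(=O)Nc3ccc(Oc4ccnc5[nH]ccc45)c(F)c3)c2)cc1` carries a methyl where compound 2 carries an ethyl; in this assay compound 1 gives 3970 nM. The step of a 1.3-fold lower number from compound 1 to compound 2 (0.13 log units; within the scatter) is within the scatter, so compound 2 and compound 1 stand together and neither can be set above the other on these two numbers.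

Compound 3 `O=C(Nc1ccc(Oc2ccnc3[nH]ccc23)c(F)c1)c1cc(-c2ccc(F)cc2)ccn1` is the next point. Its difference from compound 2 reads fluoro in place of ethyl on an aromatic carbon: the same difference, cut one bond further out, reads 4-ethylphenyl to 4-fluorophenyl. Within the data shown here, the only measured step that bears on this position is the one from compound 1 to compound 2, which altered the same group and stayed within the scatter. That is a thin base for expecting any movement. The expectation for compound 3 in this assay is therefore a step of a 1.2-fold higher number from compound 2 to compound 3 (0.07 log units; within the scatter), that is no change beyond the scatter. Compound 3 is estimated at 3500 nM, with a range from 1500 nM to 8500 nM.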

Compound 3, half-maximal inhibitory concentration: 710 nM
Compound 3: middle estimate off by 4.9-fold (0.69 log units), on the high side, and the stated range ends above it.
By their numbers in this assay, from the lowest: compound 3; then compounds 2 and 1 (each within the scatter of the next).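

In this assay the group on this aromatic carbon, para to a large group, proves able to move the read-out: the earlier methyl and ethyl pair stayed within the scatter, whereas fluoro in place of ethyl gives a 4.2-fold lower number from compound 2 to compound 3 (0.62 log units; beyond the scatter), and fluoro in place of methyl gives a 5.6-fold lower number from compound 1 to compound 3 (0.75 log units; beyond the scatter). Compound 3 therefore stands apart from both alkyl compounds, and the change that counts here is from an alkyl group to fluoro, not a change in chain length. Nothing at hand accounts for the size of these steps.

With fluoro as the only non-alkyl group shown, it remains open whether the lower number belongs to fluoro itself or simply follows from removing the alkyl group. Hydrogen, chloro, methoxy or an amine on the same carbon would separate these readings.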